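The source may hold more compounds than are shown below. What is called first, only, known or untested is meant among the compounds shown, and "the series" means these compounds.

Compound 2 `CCOC(=O)CCCCCOc1cccc(CN(C(=O)c2ccc(-c3cnc(OC)nc3OC)cc2)C(C)C)c1` is the starting point here. In an ADME assay on HepG2 cells (Homo sapiens) for cytotoxicity, read by CellTiter-Glo and resazurin assay, with a stated time of 72 h (a higher number here means that more compound is needed for the effect, a lower number that less compound is needed), compound 2 gives > 26000 nM, and this is a limit of the assay rather than a measured number. Its parent, compound 1 `CCOC(=O)CCCCCOc1cccc(CN(C(=O)c2ccccc2)C(C)C)c1`, carries hydrogen where compound 2 carries the 2,4-dimethoxypyrimidin-5-yl group. In this assay compound 1 gives > 26000 nM, which is again a limit. Both values sit at the same limit, as shown by the limit of > 26000 nM in this assay, at which 2 of the 2 values shown sit, so the step that the two limits leave unreadable from compound 1 to compound 2 cannot be read: it could be small or large in either direction, with the top of the measured range hiding it.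

The new compound 3 `CCOC(=O)CCCCCOc1cccc(CN(C(=O)c2ccc(-c3cccc(C(C)=O)c3)cc2)C(C)C)c1` differs from compound 2 by 3-acetylphenyl in place of 2,4-dimethoxypyrimidin-5-yl on an aromatic carbon. Among the compounds with values here, the only measured step that touches this position is the unreadable one from compound 1 to compound 2, so there is nothing that sets a direction or a size for the change in this assay. Since both known compounds sit at the limit, compound 3 is expected to sit there too, with a step that the limit leaves unreadable from compound 2 to compound 3 amounting to no readable change. For compound 3 the expected value in this assay is 35000 nM, with a likely range from 15000 nM to 100000 nM, and most probably the assay will again report only a limit.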

Compound 3, half-maximal effective concentration: > 26000 nM
Compound 3: a limit, no number; the forecaster's own chance of this, stated with the estimate: 75%; the middle value does not contradict the limit.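

In this assay compound 3 gives > 26000 nM, which is a limit and not a number. No step among compound 1, compound 2 and compound 3 can be read, because all three sit at the same limit: the limit of > 26000 nM in this assay, at which 3 of the 3 values shown sit.

The compounds shown leave open whether the 2,4-dimethoxypyrimidin-5-yl or 3-acetylphenyl group changes the result in this assay at all.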